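A Hydroxy Group on the Core of Compound 3

The source may hold more compounds than are shown below. What is called first, only, known or untested is meant among the compounds shown, and "the series" means these compounds.

In a functional assay for inhibition (on this read-out higher numbers stand for weaker inhibition and lower numbers for stronger inhibition), compound 1 `CC(C)(C)c1cc(-c2cc(=O)c3ccc(OCc4ccc(Cl)cc4)cc3o2)cc(C(C)(C)C)c1O` gives 7000 nM, compound 2 `CC(C)(C)c1cc(-c2cc(=O)c3ccc(OCC(=O)N4CCCCC4)cc3o2)cc(C(C)(C)C)c1O` gives 3000 nM, and compound 3 `CC(C)(C)c1cc(-c2cc(=O)c3ccccc3o2)cc(C(C)(C)C)c1O` gives 3000 nM. Compound 3 thus stands level with compound 2, and together they hold the lowest of the three numbers. Compound 4 `CC(C)(C)c1cc(-c2cc(=O)c3ccc(O)cc3o2)cc(C(C)(C)C)c1O` carries hydroxy in place of hydrogen on an aromatic carbon of compound 3 (hydroxy in place of hydrogen on an aromatic carbon). This is the carbon that bears the oxygen-linked groups of compound 1 and compound 2, so two measured steps bear on the change. Replacing (4-chlorobenzyl)oxy with hydrogen gives a 2.3-fold lower number from compound 1 to compound 3 (0.37 log units; beyond the scatter), a modest step. Replacing ((piperidin-1-yl)carbonyl)methoxy with hydrogen gives no change at the digits printed from compound 2 to compound 3 (within the scatter). Going by the values given here, no measured compound has a free hydroxy there, so the direction remains open. Neither step suggests a large effect at this carbon, and no shift beyond the scatter is expected in this assay. The expected outcome is no change at the digits printed from compound 3 to compound 4 (within the scatter). For compound 4 the estimated value is 3000 nM, within an expected range of 1200 nM to 7000 nM.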

Compound 4, half-maximal inhibitory concentration: 1000 nM
Compound 4: the middle estimate sits 3.0-fold (0.48 log units) above what was measured; measured number below the stated range.
By their numbers in this assay, from the lowest: compound 4; then compounds 2 and 3 (each within the scatter of the next); then compound 1.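

In this assay, hydroxy on this aromatic carbon gives a 3.0-fold lower number from compound 3 to compound 4 (0.48 log units; beyond the scatter), the first step shown in which a group here gives a lower number than hydrogen. Oxygen on this carbon is therefore not a drawback in itself, and what sits on that oxygen matters: hydrogen in place of ((piperidin-1-yl)carbonyl)methyl gives a 3.0-fold lower number from compound 2 to compound 4 (0.48 log units; beyond the scatter), and hydrogen in place of 4-chlorobenzyl gives a 7.0-fold lower number from compound 1 to compound 4 (0.85 log units; beyond the scatter), leaving compound 4 with the lowest number of the four. Nothing measured here accounts for this gain.

The compounds shown leave open whether a methoxy group or an amine on this carbon would match the hydroxy. They also leave open whether hydroxy on another carbon of the same ring would give a similar number.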